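Replacing the acetyl methyl with 2-chlorophenyl on the amide carbon

The source may report more compounds than this note shows. Statements on the series, on what has been measured and on what is new or still open speak of the compounds shown alone.

Measured so far in a toxicity assay on THP-1 cells (Homo sapiens) for inhibition; a lower number here means that less compound is tolerated, a higher number that more compound is tolerated:
- compound 1, `COc1ccc(-c2cnc(NC(=O)c3cnc[nH]3)n2C)cc1`: compound 1 gives > 100000 nM
- compound 2, `COc1ccc(-c2cnc(NC(C)=O)n2C)cc1`: compound 2 gives > 100000 nM

Both values sit at a limit of this assay rather than at a number. Compound 2 gives only the limit > 100000 nM in this assay, so its true position is open upward. Among the measured compounds shown here, the one measured step, a step that the two limits leave unreadable from compound 1 to compound 2, is unreadable, since both its ends rest on (the limit of > 100000 nM in this assay, at which 2 of the 2 values shown sit).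

Compound 3, `COc1ccc(-c2cnc(NC(=O)c3ccccc3Cl)n2C)cc1`, is the next compound. It differs from compound 2 by 2-chlorophenyl in place of methyl on a carbonyl carbon. For the measured compounds named here, no measured step bears directly on this change; the only step on record, from compound 1 to compound 2, is itself unreadable, so there is nothing to size the step against. With both measured compounds tolerated up to the limit, the expectation is that compound 3 stays in the same region and that any movement is not readable beyond the scatter. Compound 3 is expected near 100000 nM, in a range from 30000 nM to 300000 nM. The expected step of a number no higher from compound 2 to compound 3 (the limit leaves the size open) is therefore small.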

Compound 3, half-maximal cytotoxic concentration: > 50000 nM
Compound 3 was reported as a limit (the forecaster's own chance of this, stated with the estimate: 60%); the middle value is on the limit's open side.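

In this assay compound 3 gives > 50000 nM, which is a limit and not a number. No step joining compound 3 to compound 1 or compound 2 can be read, because each rests on limits at both ends: the limit of > 50000 nM in this assay, at which 1 of the 3 values shown sits.

The compounds shown leave open whether 2-chlorophenyl, methyl or 1H-imidazol-5-yl on the carbonyl carbon makes any difference in this assay.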